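The source may hold more compounds than are shown below. What is called first, only, known or untested is meant among the compounds shown, and "the series" means these compounds.

Compound 2, `Nc1ncccc1-c1nc2cc(-c3cccnc3)cnc2n1-c1ccc(CNC(=O)c2ccccc2)cc1`, is the reference point here. In an in vitro assay on Sf9 cells for inhibition of RAC-alpha serine/threonine-protein kinase (Homo sapiens), read by AlphaScreen, with a stated time of 20 min (on this read-out higher numbers stand for weaker inhibition and lower numbers for stronger inhibition), compound 2 gives 8 nM, the lowest of the two numbers recorded. The nearest measured neighbour is compound 1, `CC(=O)NCc1ccc(-n2c(-c3cccnc3N)nc3cccnc32)cc1`, which in this assay gives 810 nM; that gap lies well beyond the scatter of repeated measurements, so compound 2 is clearly the stronger inhibitor of the two. The third compound, compound 3 with structure `COc1ccccc1Cn1c(-c2ccncc2)nc2cc(Br)cnc21`, is a different case: in this assay compound 3 reaches only the limit of the assay, > 300000 nM, so no number is attached to it.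

The unmeasured compound 4, `Nc1ncccc1-c1nc2cc(C3CCCC3)cnc2n1-c1ccc(CNC(=O)c2ccccc2)cc1`, keeps the core and the side chain of compound 2 and changes a single group on the fused ring system: cyclopentyl in place of pyridin-3-yl on an aromatic carbon. For the measured compounds named here, nothing among the measured pairs differs in exactly this way, so the size of the step has to be guessed. The expectation is that the step in this assay from compound 2 to compound 4 goes toward a weaker inhibition, by a modest amount that exceeds the usual scatter, a 5.0-fold higher number from compound 2 to compound 4 (0.70 log units; beyond the scatter). On that basis compound 4 is estimated to give about 40 nM in this assay, with a likely range from 8 nM to 200 nM.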

Compound 4, half-maximal inhibitory concentration: 110 nM
For compound 4 the middle estimate is 2.8-fold (0.44 log units) below the measured one; the range from low to high includes it.
By their numbers in this assay, from the lowest: compound 2; then compound 4; then compound 1. At a limit, above all of these: compound 3.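

Compound 2 and compound 4 form the only pair shown that differs in one place, so they give a direct reading of the group on this aromatic carbon: in this assay cyclopentyl in place of pyridin-3-yl gives a 14-fold higher number from compound 2 to compound 4 (1.14 log units; beyond the scatter) and the group here clearly matters to inhibition. The change is not a single feature, however, since the aromatic six-membered ring, its ring nitrogen and its hydrogen-bond acceptor all leave together, while a five-membered non-aromatic ring of carbon only enters, and the step cannot divide its size among these differences. Nothing among the data shown explains why this step is so large.

As far as these compounds go, it remains open how a phenyl or a cyclohexyl ring would read at this position, and such groups could help separate the part played by the ring nitrogen from that of aromaticity. From the compounds shown here alone, the effect of a small group such as methyl or an amine on this carbon also remains open, as does whether the same step would hold with another side chain.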